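Swapping 2-Fluorophenyl for 3-Hydroxyphenyl on the Carbonyl Carbon

A few compounds are considered here, and "the series" means these few. Any claim that something is new, unique, unknown or untested is made for them only; others in the source may bear on it.

Compound 1 `O=C(/C=C/c1ccc2c(c1)B(O)OC2)c1ccc(F)cc1` gives 7600 nM in a toxicity assay on WI-38 cells (Homo sapiens) for cytotoxicity, read by MTT assay, with a stated time of 48 h; a higher number here means a weaker inhibitor, a lower number a stronger inhibitor.
Compound 2 `O=C(/C=C/c1ccc2c(c1)B(O)OC2)c1ccc(I)cc1` reaches only the assay limit > 100000 nM in this assay.
Compound 3 `O=C(/C=C/c1ccc2c(c1)B(O)OC2)c1ccccc1F` gives 23600 nM in this assay.

Of the two numbers shown, compound 3 holds the higher one; its nearest neighbour is compound 1, with a 3.1-fold higher number from compound 1 to compound 3 (0.49 log units; beyond the scatter). Set against compound 2 the comparison is an at least 4.2-fold lower number from compound 2 to compound 3 (0.62 log units; beyond the scatter), which rests on (the limit of > 100000 nM in this assay, at which 1 of the 3 values shown sits).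

Compound 4 `O=C(/C=C/c1ccc2c(c1)B(O)OC2)c1cccc(O)c1` differs from compound 3 only in the group attached to the carbonyl carbon: 3-hydroxyphenyl in place of 2-fluorophenyl on a carbonyl carbon. Among the measured compounds shown here, no measured step puts a hydroxy group in place of a fluoro group. The two steps that alter the group at this same place were a 3.1-fold higher number from compound 1 to compound 3 (0.49 log units; beyond the scatter) and an at least 13-fold higher number from compound 1 to compound 2 (1.11 log units; beyond the scatter), one modest and one large, so an exchange here has moved the number well beyond the scatter, in both directions. For the measured compounds named here, with no direct precedent for a hydroxy group, a modest shift is expected, a 1.6-fold lower number from compound 3 to compound 4 (0.20 log units; within the scatter). Compound 4 is therefore estimated at 15000 nM, within a range from 4000 nM to 70000 nM.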

Compound 4, half-maximal inhibitory concentration: 26400 nM
The estimate for compound 4 lay 1.8-fold (0.25 log units) below the measured number, within the range that was stated.
By their numbers in this assay, from the lowest: compound 1; then compounds 3 and 4 (each within the scatter of the next). At a limit, above all of these: compound 2.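

In this assay, 3-hydroxyphenyl and 2-fluorophenyl on the carbonyl carbon cannot be told apart, with a 1.1-fold higher number from compound 3 to compound 4 (0.05 log units; within the scatter), so a group with a hydrogen-bond donor can enter at this place without moving the number beyond the scatter. The 4-fluorophenyl group still gives the lowest number of the set, with a 3.5-fold higher number from compound 1 to compound 4 (0.54 log units; beyond the scatter), so the new group does not close that gap. The step from the 4-iodophenyl compound, an at least 3.7-fold lower number from compound 2 to compound 4 (0.57 log units; beyond the scatter), is only a bound, and it rests on a limit of the assay: the limit of > 100000 nM in this assay, at which 1 of the 4 values shown sits.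

Going by these compounds, it remains open how an amine or a carboxylic acid on this phenyl ring would read in this assay. A methoxy group in place of the hydroxy group would show whether the hydroxy hydrogen matters at this place at all.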